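Replacing the nitro group on the aryl sulfonamide by hydrogen

This account rests on a few compounds, and the source may have more. Where it says the series, first, only, none or still open, it means among the compounds named here.

Measured compounds:
compound 1, `O=C(O)CC/C=C\C[C@H]1[C@H](F)CC[C@@H]1NS(=O)(=O)c1ccc(Cl)c(Cl)c1`, 1700 nM
compound 2, `Cc1ccc(S(=O)(=O)N[C@H]2CC[C@@H](F)[C@@H]2C/C=C\CCC(=O)O)cc1`, 1900 nM
compound 3, `O=C(O)CC/C=C\C[C@H]1[C@H](F)CC[C@@H]1NS(=O)(=O)c1ccccc1[N+](=O)[O-]`, 560 nM

The three compounds share one core and differ only in the aryl group on the sulfonyl sulfur. In a functional assay on a cell-free system (plasma) for inhibition of thromboxane A2 receptor (Homo sapiens), read by turbidimetry (on this read-out higher numbers stand for weaker inhibition and lower numbers for stronger inhibition), compound 3 gives 560 nM, the lowest number of the three. Its nearest neighbour is compound 1, reached by a 3.0-fold lower number from compound 1 to compound 3 (0.48 log units; beyond the scatter); the largest gap is a 3.4-fold lower number from compound 2 to compound 3 (0.53 log units; beyond the scatter). Between compounds 1 and 2 the change is a 1.1-fold higher number from compound 1 to compound 2 (0.05 log units; within the scatter).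

Compound 4 is `O=C(O)CC/C=C\C[C@H]1[C@H](F)CC[C@@H]1NS(=O)(=O)c1ccccc1`. It differs from compound 3 by hydrogen in place of nitro on an aromatic carbon. Going by the values given here, no measured pair removes a substituent from the aryl ring entirely; the measured steps only swap one substituted phenyl for another, and each of them is modest in size. Both swaps that lead to the 2-nitrophenyl compound lower the number, which suggests that losing the nitro group is more likely to raise the number than to lower it, by an amount comparable to those steps.

Compound 4 is therefore expected to lie near 1500 nM, between 500 nM and 5000 nM, which corresponds to the expected step of a 2.7-fold higher number from compound 3 to compound 4 (0.43 log units; beyond the scatter).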

Compound 4, half-maximal inhibitory concentration: 2000 nM
Estimate against measurement, compound 4: 1.3-fold (0.12 log units) below; low and high end bracket the measured number.
By their numbers in this assay, from the lowest: compound 3; then compounds 1, 2 and 4 (each within the scatter of the next).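

In this assay, going by these compounds alone, taking the nitro group off gives a 3.6-fold higher number from compound 3 to compound 4 (0.55 log units; beyond the scatter), the first step at this position that starts from a ring with no substituent at all. The plain phenyl compound does not separate from the other two, with a 1.1-fold higher number from compound 2 to compound 4 (0.02 log units; within the scatter) and a 1.2-fold higher number from compound 1 to compound 4 (0.07 log units; within the scatter), so neither the 4-methylphenyl nor the 3,4-dichlorophenyl group differs from phenyl beyond the scatter, and among these four compounds only the 2-nitrophenyl compound, compound 3, stands apart. No measurement shown here offers a reason for this difference.

From the compounds shown here alone, whether the lower number belongs to the nitro group itself or would come with other groups in that place stays open, and an amine, a nitrile or a methyl on the same aromatic carbon would tell these apart. Since only the aryl group varies here, the compounds also leave open how the 2-nitrophenyl gain would carry over to a shared core with a longer chain or with a tetrazole in place of the carboxylic acid.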